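A small aryl change from compound 3 to compound 4

This account rests on a few compounds, and the source may have more. Where it says the series, first, only, none or still open, it means among the compounds named here.

Measured so far in a functional assay on MCF7 cells (Homo sapiens) for cytotoxicity, read by MTT assay, with a stated time of 72 h; a higher number here means a weaker inhibitor, a lower number a stronger inhibitor:
- compound 1 `O=C(N/N=C/c1ccc(F)cc1)Nc1cc2c(Nc3ccc(F)c(Cl)c3)ncnc2cc1O[C@H]1CCOC1`: 28200 nM
- compound 2 `N#Cc1ccc(/C=N/NC(=O)Nc2cc3c(Nc4ccc(F)c(Cl)c4)ncnc3cc2O[C@H]2CCOC2)cc1`: "not determined" (no result reported)
- compound 3 `O=C(N/N=C/c1ccc(F)cc1Cl)Nc1cc2c(Nc3ccc(F)c(Cl)c3)ncnc2cc1O[C@H]1CCOC1`: 32200 nM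

Only two of these entries carry a number, so there is little to go on. Compound 3, at 32200 nM, lies within the usual scatter of compound 1, at 28200 nM, so the two cannot be told apart.

The next compound is compound 4 `O=C(N/N=C/c1cccc(Cl)c1Cl)Nc1cc2c(Nc3ccc(F)c(Cl)c3)ncnc2cc1O[C@H]1CCOC1`, which differs from compound 3 in one group: 2,3-dichlorophenyl in place of 2-chloro-4-fluorophenyl on a carbon with a double bond to nitrogen. In words, 2,3-dichlorophenyl stands in place of 2-chloro-4-fluorophenyl on a carbon with a double bond to nitrogen.

Among the measured compounds shown here, the only measured step that bears on this change is a 1.1-fold higher number from compound 1 to compound 3 (0.06 log units; within the scatter), where a chloro replaced hydrogen on an aromatic carbon. That single step is a thin guide, but it gives no reason to expect a real shift, and compound 2 adds no number. The expected step is a 1.1-fold lower number from compound 3 to compound 4 (0.03 log units; within the scatter), with no change in either direction beyond the scatter. For compound 4 the estimated value in this assay is 30000 nM, with an expected range from 15000 nM to 60000 nM.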

Compound 4, half-maximal inhibitory concentration: "not active" (no number reported)
No number was reported for compound 4; the estimate stays without a comparison.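

In this assay, among the compounds shown here, compound 4 is reported as not active, without a number, so no step from compound 3 to compound 4 can be read. Nothing measured here explains this result. The compounds shown leave open how far 2,3-dichlorophenyl in place of 2-chloro-4-fluorophenyl shifts cytotoxicity.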